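A few compounds are considered here, and "the series" means these few. Any claim that something is new, unique, unknown or untested is made for them only; others in the source may bear on it.

Compound 3 `Fc1ccc(Nc2nc(SCc3ccc(C(F)(F)F)cc3)nc3ccccc23)cc1` gives 36300 nM in a functional assay on MCF7 cells (Homo sapiens) for cytotoxicity, read by MTT assay, with a stated time of 72 h; a lower number here means a stronger inhibitor, a higher number a weaker inhibitor. Compound 1 `FC(F)(F)c1ccc(CSc2nc(Nc3ccccc3)c3ccccc3n2)cc1`, which carries a plain phenyl on the same nitrogen, gives 44000 nM in this assay, and the step of a 1.2-fold lower number from compound 1 to compound 3 (0.08 log units; within the scatter) does not separate the two. Compound 2 `COc1ccccc1Nc1nc(SCc2ccc(C(F)(F)F)cc2)nc2ccccc12` reaches only the limit of this assay, reported as > 50000 nM. That limit, described as the limit of > 50000 nM in this assay, at which 1 of the 3 values shown sits, is the only point of reference for a methoxy on this ring: the step of an at least 1.1-fold higher number from compound 1 to compound 2 (0.05 log units; that floor lies within the scatter) and the step of an at least 1.3-fold lower number from compound 2 to compound 3 (0.13 log units; that floor lies within the scatter) both run toward the limit side when a methoxy is present.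

Compound 4 `COc1ccc(Nc2nc(SCc3ccc(C(F)(F)F)cc3)nc3ccccc23)c(OC)c1` differs from compound 3 by 2,4-dimethoxyphenyl in place of 4-fluorophenyl on a nitrogen on an aromatic ring. Of the measured steps, the two that involve compound 2 bear on this change, since compound 2 alone carries a methoxy on the ring attached to the nitrogen, and both of those steps reached only a floor. Compound 4 carries two methoxy groups on that ring, so the expected direction in this assay is toward a higher number, with a real chance that only a limit is returned. The estimated step of a 1.7-fold higher number from compound 3 to compound 4 (0.22 log units; within the scatter) is therefore expected to be modest at most. For compound 4 the expected value is 60000 nM, with a range from 30000 nM to 150000 nM.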

Compound 4, half-maximal inhibitory concentration: > 50000 nM
Compound 4 ended at the assay's limit; the forecaster's own chance of this, stated with the estimate: 55%; the middle value is on the limit's open side.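

In this assay, within the data shown here, compound 4 stops at a limit and not at a number, so a second methoxy on the ring attached to the nitrogen returns no more of a readable value than the single methoxy of compound 2 did. The steps of an at least 1.3-fold higher number from compound 3 to compound 4 (0.13 log units; that floor lies within the scatter) and an at least 1.1-fold higher number from compound 1 to compound 4 (0.05 log units; that floor lies within the scatter) are both floors, so they give no measured size for this change, and the step between the two methoxy-bearing compounds cannot be read. What the result adds is a count, not a size: both compounds with a methoxy on this ring sit at the limit, while the phenyl and 4-fluorophenyl compounds return numbers, and none of the four compounds shown goes against this: the limit of > 50000 nM in this assay, at which 2 of the 4 values shown sit.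

On these data alone, how far past the limit compound 2 and compound 4 lie remains unknown, as does whether adding the second methoxy changes anything at all. As far as these compounds go, it also remains open whether an amine or a carboxylic acid on this ring would give a number clearly apart from those of compound 1 and compound 3.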